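Nitro for Hydrogen on the Aniline Ring of Compound 2

A few compounds are considered here, and "the series" means these few. Any claim that something is new, unique, unknown or untested is made for them only; others in the source may bear on it.

Measured compounds:
Compound 1, `Clc1ccc(Nc2ccc(N3CC4CC(C3)N4)cn2)cc1`, in an assay on cell membranes for displacement of a labelled ligand from Neuronal acetylcholine receptor; alpha4/beta2 (Rattus norvegicus) (on this read-out higher numbers stand for weaker inhibition and lower numbers for stronger inhibition), compound 1 gives 2.49 nM.
Compound 2, `c1ccc(Nc2ccc(N3CC4CC(C3)N4)cn2)cc1`, in this assay compound 2 gives 2.66 nM.

Going by the values given here, compound 2 stands alongside compound 1, the only other measured compound, and the two lie within the scatter of each other: the step of a 1.1-fold higher number from compound 1 to compound 2 (0.03 log units; within the scatter) shows that removing the chloro from the aromatic carbon left the number essentially unchanged.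

Compound 3, `O=[N+]([O-])c1ccc(Nc2ccc(N3CC4CC(C3)N4)cn2)cc1`, carries the change (nitro in place of hydrogen on an aromatic carbon). Among the compounds with values here, the only measured step that bears on it is a 1.1-fold higher number from compound 1 to compound 2 (0.03 log units; within the scatter), which concerns the same aromatic carbon and a different group; it was flat. Within the data shown here, that single step gives no sign that a group at this position moves the number, but nitro is not chloro, and no measured step covers nitro. In this assay the expectation for compound 3 is therefore a step of a 1.2-fold higher number from compound 2 to compound 3 (0.08 log units; within the scatter), that is, no change beyond the scatter, with a wide range to allow for the untested group. The estimate for compound 3 is 3.2 nM, between 1 nM and 12 nM.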

Compound 3, inhibition constant: 1.76 nM
Beside the measured number, compound 3's estimate is 1.8-fold (0.26 log units) above it, within the range that was stated.
By their numbers in this assay, from the lowest: compounds 3, 1 and 2 (each within the scatter of the next).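

In this assay the position now carries a third group, and the step of a 1.5-fold lower number from compound 2 to compound 3 (0.18 log units; within the scatter) lies within the scatter, as does the step of a 1.4-fold lower number from compound 1 to compound 3 (0.15 log units; within the scatter) in the same assay. Until now, this aromatic carbon of the six-membered ring, para to a large group, had been seen only with chloro and hydrogen; compound 3 extends the flat picture to nitro, a group of 3 heavy atoms with 2 hydrogen-bond acceptors, so none of the three groups shown here can be told apart from the others by its number. Nothing shown here offers an explanation for this flat picture.

As far as these compounds go, what remains open is whether the same holds for other groups on this carbon, such as an amine, a carboxylic acid or a longer chain, any of which might give a step beyond the scatter. The compounds shown also leave open whether a group on another carbon of this ring would behave in the same way, and whether the flat picture would survive a change to the shared core.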